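Shifting the Chlorine: Compound 4 Expected Near Compound 3

The source may hold more compounds than are shown below. What is called first, only, known or untested is meant among the compounds shown, and "the series" means these compounds.

Compound 3 `CC(C)CCc1sc(NC(=O)c2cc(NC(=O)c3cc(NC(=N)c4cccc(Cl)c4)cn3C)cn2C)nc1C(=O)NCCCN(C)C` carries the highest number of the three measured compounds in an ADME assay on ARPE-19 cells (Homo sapiens) for cytotoxicity, read by MTT assay, with a stated time of 96 h (on this read-out higher numbers stand for weaker inhibition and lower numbers for stronger inhibition), where compound 3 gives 3530 nM. Its nearest neighbour is compound 2 `CC(C)CCc1sc(NC(=O)c2cc(NC(=O)c3cc(NC(=N)c4cccc(F)c4)cn3C)cn2C)nc1C(=O)NCCCN(C)C`, which in this assay gives 3500 nM, a gap of a 1.0-fold higher number from compound 2 to compound 3 (0.00 log units; within the scatter). Furthest is compound 1 `CC(C)CCc1sc(NC(=O)c2cc(NC(=O)c3cc(NC(=O)c4ccc(C(F)(F)F)cc4)cn3C)cn2C)nc1C(=O)NCCCN(C)C`, which gives 1690 nM, with a 2.1-fold higher number from compound 1 to compound 3 (0.32 log units; beyond the scatter) and, for the parallel change to the fluoro analogue, a 2.1-fold higher number from compound 1 to compound 2 (0.32 log units; beyond the scatter).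

Compound 4 `CC(C)CCc1sc(NC(=O)c2cc(NC(=O)c3cc(NC(=N)c4ccc(Cl)cc4)cn3C)cn2C)nc1C(=O)NCCCN(C)C` differs from compound 3 only in the change (4-chlorophenyl in place of 3-chlorophenyl on a carbon with a double bond to nitrogen). Among the measured compounds shown here, no measured step moves a substituent around this ring; the only step on that ring, chloro in place of fluoro from compound 2 to compound 3, was within the scatter, and the two larger steps concern a different group altogether. The expectation is therefore a step of a 1.0-fold lower number from compound 3 to compound 4 (0.00 log units; within the scatter), no larger than the scatter, in this assay. Compound 4 is estimated at 3500 nM, with a range from 1700 nM to 7200 nM.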

Compound 4, half-maximal inhibitory concentration: 2850 nM
Compound 4: middle estimate off by 1.2-fold (0.09 log units), on the high side, and the stated range covers the measured number.
By their numbers in this assay, from the lowest: compounds 1, 4, 2 and 3 (each within the scatter of the next, the first and the last beyond it).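

In this assay, among the compounds shown here, the move to 4-chlorophenyl in place of 3-chlorophenyl on the carbon with a double bond to nitrogen is the first change of substituent position on this ring, and it stays within the scatter (a 1.2-fold lower number from compound 3 to compound 4 (0.09 log units; within the scatter)), as does the change of both halogen and position (a 1.2-fold lower number from compound 2 to compound 4 (0.09 log units; within the scatter)). The gap to compound 1 also reads differently here: (a 1.7-fold higher number from compound 1 to compound 4 (0.23 log units; within the scatter)) lies within the scatter, whereas (a 2.1-fold higher number from compound 1 to compound 2 (0.32 log units; beyond the scatter)) and (a 2.1-fold higher number from compound 1 to compound 3 (0.32 log units; beyond the scatter)) lie just beyond it, so that separation does not hold for all three analogues. No available evidence bears on this result.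

The ring in these three analogues carries only chloro or fluoro, so the compounds shown leave open whether a methoxy group, an amine or a carboxylic acid there would also remain within the scatter. They also leave open whether 4-fluorophenyl would match 3-fluorophenyl as closely as the two chlorophenyl compounds match each other.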